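A few compounds are considered here, and "the series" means these few. Any claim that something is new, unique, unknown or untested is made for them only; others in the source may bear on it.

Compound 1 `CCNC(=O)c1cc(Oc2ccc(NC(=O)c3nn(-c4ccc(Br)cc4F)c(=O)cc3C)cc2)ccn1` gives 35100 nM
Compound 2 `CCCNC(=O)c1cc(Oc2ccc(NC(=O)c3nn(-c4cccc(F)c4)c(=O)cc3C)cc2F)ccn1` gives 13300 nM
Compound 3 `CNC(=O)c1cc(Oc2ccc(NC(=O)c3nn(-c4cccc(C(F)(F)F)c4)c(=O)cc3C)cc2F)ccn1` gives 45800 nM

All three values come from a functional assay on MCF7 cells (Homo sapiens) for antiproliferative activity, read by MTT assay, with a stated time of 72 h (a higher number here means a weaker inhibitor, a lower number a stronger inhibitor), and nothing else. Compound 1 cannot be told apart from compound 3 within the usual scatter, while compound 2 gives a clearly lower number than compound 1. The step to compound 4 (`CCNC(=O)c1cc(Oc2ccc(NC(=O)c3nn(-c4cccc(C(F)(F)F)c4)c(=O)cc3C)cc2)ccn1`) puts 3-(trifluoromethyl)phenyl in place of 4-bromo-2-fluorophenyl on an aromatic nitrogen. Among the compounds with values here, no measured pair isolates this swap, so the expectation is rough. Only a small step is expected in this assay since compound 3 with the same group gives 45800 nM here. The estimated step is a 1.1-fold higher number from compound 1 to compound 4 (0.03 log units; within the scatter) and stays within the scatter. For compound 4 the estimate is 38000 nM with an expected range of 15000 nM to 90000 nM in this measurement.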

Compound 4, half-maximal inhibitory concentration: 40600 nM
The estimate for compound 4 lay 1.1-fold (0.03 log units) below the measured number; measured number inside the range.
By their numbers in this assay, from the lowest: compound 2; then compounds 1, 4 and 3 (each within the scatter of the next).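

In this assay, within the data shown here, the swap of 4-bromo-2-fluorophenyl for 3-(trifluoromethyl)phenyl on the aromatic nitrogen gives a 1.2-fold higher number from compound 1 to compound 4 (0.06 log units; within the scatter), the only comparison here in which just one place changes. At this position, then, these two substituted phenyl groups cannot be told apart, even though the entering group has more heavy atoms. Nothing measured here offers an explanation for this result. From the compounds shown here alone, it remains open whether a phenyl ring carrying an amine or a carboxylic acid at this position would shift the number beyond the scatter.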